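Nitrile to Aminomethoxy Analogue: an Expected Gain in Potency

The source may hold more compounds than are shown below. What is called first, only, known or untested is meant among the compounds shown, and "the series" means these compounds.

Compounds measured so far:
compound 1, `COc1cc(-c2ccnc3cc(-c4cccc(C#N)c4)nn23)cc(OC)c1OC`: > 10000 nM
compound 2, `COc1ccc(-c2cc3nccc(-c4cc(OC)c(OC)c(OC)c4)n3n2)cc1`: 125 nM
compound 3, `COc1cc(-c2ccnc3cc(-c4ccc5cnn(C)c5c4)nn23)cc(OC)c1OC`: 279 nM

All three share one core and differ only in the aromatic group attached to it; they were compared in a functional assay on MCF7 cells (Homo sapiens) for inhibition, read by CCK-8 assay, with a stated time of 48 h; a lower number here means a stronger inhibitor, a higher number a weaker inhibitor. Compound 1 reached only a limit of the measurement, > 10000 nM, so no number is known for it and its true value sits at or beyond (the limit of > 10000 nM in this assay, at which 1 of the 3 values shown sits). Compound 2 gives 125 nM in this assay, and compound 3 gives 279 nM. Both substitutions away from the 3-cyanophenyl of compound 1 brought large gains: an at least 80-fold lower number from compound 1 to compound 2 (1.90 log units; beyond the scatter) and an at least 35-fold lower number from compound 1 to compound 3 (1.55 log units; beyond the scatter). Between the two, the difference is only modest: a 2.2-fold higher number from compound 2 to compound 3 (0.35 log units; beyond the scatter).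

Compound 4, `COc1ccc(-c2cc3nccc(-c4cc(OC)c(OC)c(OC)c4)n3n2)cc1N`, has not yet been measured. Relative to compound 1 the change is 3-amino-4-methoxyphenyl in place of 3-cyanophenyl on an aromatic carbon. For the measured compounds named here, this new group keeps the methoxy seen in compound 2 and adds an amino group, so the step that bears most directly on it is the one from compound 1 to compound 2, which was large. A gain of similar size is therefore expected, ending in the region of compound 2.

Compound 4 is estimated to give about 150 nM in this assay, most likely between 40 nM and 600 nM. That estimate corresponds to an expected step of an at least 66-fold lower number from compound 1 to compound 4 (1.82 log units; beyond the scatter).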

Compound 4, half-maximal inhibitory concentration: 27 nM
For compound 4 the middle estimate is 5.6-fold (0.74 log units) above the measured one; measured number below the stated range.
By their numbers in this assay, from the lowest: compound 4; then compound 2; then compound 3. At a limit, above all of these: compound 1.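

Adding an amino group to the 4-methoxyphenyl ring of compound 2 gives, in this assay, a 4.6-fold lower number from compound 2 to compound 4 (0.67 log units; beyond the scatter), so this position responds to a single added group on a ring that already works, not only to the removal of the 3-cyanophenyl group. Set against the 1-methyl-1H-indazol-6-yl group, the 3-amino-4-methoxyphenyl group gives a 10-fold lower number from compound 3 to compound 4 (1.01 log units; beyond the scatter), and compound 4 now has the lowest number of the four, with its steps to compound 2 and compound 3 both printed as beyond the usual scatter. Set against the 3-cyanophenyl group, the change gives an at least 370-fold lower number from compound 1 to compound 4 (2.56 log units; beyond the scatter), a figure that is only a minimum, because compound 1 stands at a limit and not at a number: the limit of > 10000 nM in this assay, at which 1 of the 4 values shown sits.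

The compounds shown leave open whether the gain belongs to the amino group specifically, or whether a hydroxyl, a methylamino or an acetamide in its place would give a similar number. They also leave open how much the methoxy contributes, and whether a 3-aminophenyl group alone would hold the same level in this assay.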